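Compound 3 and a Chloro Added to Its Benzoyl Ring

The source may report more compounds than this note shows. Statements on the series, on what has been measured and on what is new or still open speak of the compounds shown alone.

Measured so far in a functional assay on CHO cells for agonist activity at adenosine receptor A1 (Homo sapiens), read by fluorescence and ERK phosphorylation, with stated times of 30 min and 1.5 h, tested at 3 uM; a lower number here means a weaker effect, a higher number a stronger effect of the compound at the concentration tested:
compound 1 `Nc1scc(-c2cccc(C(F)(F)F)c2)c1C(=O)c1ccccc1` gives 83%
compound 2 `Nc1scc(-c2ccc(I)cc2)c1C(=O)c1ccccc1` gives 51%
compound 3 `Nc1scc(-c2cc(C(F)(F)F)cc(C(F)(F)F)c2)c1C(=O)c1ccccc1` gives 83%

Compound 3 stands level with compound 1 at the digits shown, and these two are together the highest of the three numbers. Among the measured compounds shown here, the only single-place step among the measured compounds, no change at the digits printed from compound 1 to compound 3 (within the scatter), adds a second trifluoromethyl to the aryl ring that hangs from the shared core and leaves the read-out unchanged within the scatter. For the measured compounds named here, compound 2, which carries an iodo group on that aryl ring instead, gives a number well below compound 3 in this assay, though it differs in more than one place and so gives no single step.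

Compound 4 `Nc1scc(-c2cc(C(F)(F)F)cc(C(F)(F)F)c2)c1C(=O)c1ccc(Cl)cc1` differs from compound 3 in one place: chloro in place of hydrogen on an aromatic carbon. Going by the values given here, this alteration sits on the benzoyl ring, a part of the molecule that no measured step touches; the one step available, from compound 1 to compound 3, concerns the other ring and was flat. There is therefore no measured basis for a shift, and the expectation is that a number 3 percentage points lower from compound 3 to compound 4 (within the scatter) stays within the scatter. Compound 4 is accordingly estimated at 80% in this assay, with a range from 60% to 95%.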

Compound 4, a percentage reported as activity, at one concentration (the size of the read-out at that concentration, not a potency): 69%
Compound 4: the middle estimate sits 11 percentage points above what was measured; low and high end bracket the measured number.
By their numbers in this assay, from the lowest: compound 2; then compound 4; then compounds 1 and 3 (each within the scatter of the next).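

Among the compounds shown here, the benzoyl ring is not a silent part of the molecule in this assay: chloro on an aromatic carbon of this ring, para to a large group, gives a number 14 percentage points lower from compound 3 to compound 4 (beyond the scatter), whereas the one earlier step, on the other aryl ring, was no change at the digits printed from compound 1 to compound 3 (within the scatter). Among the compounds shown, this is the only sign that a change on the benzoyl ring can move the number, and it moves it down, with compound 4 still giving 69%. No measurement at hand says why the number falls.

A single chloro at a single place cannot show whether the fall belongs to chloro itself or to any group placed there, and a methoxy, an amine or a carboxylic acid at that carbon would speak to this, as would chloro on another carbon of the same ring. Also open, going by these compounds, is whether the same chloro on the benzoyl ring of compound 1, with its single trifluoromethyl, would give a step of similar size.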